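Chloro for Fluoro on the Sulfonyl Aryl Ring

The source may hold more compounds than are shown below. What is called first, only, known or untested is meant among the compounds shown, and "the series" means these compounds.

Compound 1 `O=C1/C(=C/c2cccnc2)CN(S(=O)(=O)c2ccc(F)cc2)C/C1=C\c1ccccc1F`: 15600 nM
Compound 2 `O=C1/C(=C/c2cccnc2)CN(S(=O)(=O)c2ccc(Cl)cc2)C/C1=C\c1ccccc1F`: 12400 nM
Compound 3 `O=C1/C(=C/c2ccncc2)CN(S(=O)(=O)c2ccc(F)cc2)C/C1=C\c1ccccc1C(F)(F)F`: 4010 nM

In a functional assay on HepG2 cells (Homo sapiens) for cytotoxicity, read by MTT assay, with a stated time of 24 h (on this read-out lower numbers stand for stronger inhibition and higher numbers for weaker inhibition), compound 1 gives 15600 nM and compound 2 gives 12400 nM. The change between them is chloro in place of fluoro on an aromatic carbon, and it made a 1.3-fold lower number from compound 1 to compound 2 (0.10 log units; within the scatter). Compound 3 gives 4010 nM, the lowest number of the three, with its gap to both others beyond the scatter. How the core of compound 1 differs from the core of compound 3 is not broken down here.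

Compound 4 `O=C1/C(=C/c2ccncc2)CN(S(=O)(=O)c2ccc(Cl)cc2)C/C1=C\c1ccccc1C(F)(F)F` is not yet measured. It differs from compound 3 by chloro in place of fluoro on an aromatic carbon, the same change as between compound 1 and compound 2. Because a 1.3-fold lower number from compound 1 to compound 2 (0.10 log units; within the scatter) stayed within the scatter, a similarly small step is expected here, a 1.3-fold lower number from compound 3 to compound 4 (0.10 log units; within the scatter). The estimate for compound 4 in this assay is therefore 3200 nM, expected to fall between 1500 nM and 7000 nM.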

Compound 4, half-maximal inhibitory concentration: 7190 nM
Estimate against measurement, compound 4: 2.2-fold (0.35 log units) below; the whole stated range lies below it.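

In this assay, going from (4-fluorophenyl)sulfonyl to (4-chlorophenyl)sulfonyl on the core of compound 3 gives a 1.8-fold higher number from compound 3 to compound 4 (0.25 log units; within the scatter). Set beside the same change on the core of compound 1, the two steps cannot be told apart: the same change on two cores in this assay, a 1.3-fold lower number (0.10 log units; within the scatter) from compound 1 to compound 2 and a 1.8-fold higher number (0.25 log units; within the scatter) from compound 3 to compound 4, 2.3-fold (0.35 log units) apart, within the scatter of two such steps. So on these two cores the swap stays a small step whichever core carries it, but two pairs cannot show that this would hold on a third core, nor why the step is small.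

The compounds shown carry only fluoro or chloro at this place on the 4-substituted phenyl. Going by these compounds, what an amine, a carboxylic acid or a longer chain would do there remains open.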